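A few compounds are considered here, and "the series" means these few. Any claim that something is new, unique, unknown or untested is made for them only; others in the source may bear on it.

Measured compounds:
- compound 1, `CCCCCCCN1CCC(C(=O)Nc2cc(Cl)c(N)cc2OC)CC1`, > 10 mg/kg (a limit of the assay, not a number)
- compound 2, `COc1cc(N)c(Cl)cc1NC(=O)C1CCN(Cc2ccc(F)cc2)CC1`, 0.6 mg/kg
- compound 3, `COc1cc(N)c(Cl)cc1NC(=O)C1CCN(CC2CCCCC2)CC1`, 2.9 mg/kg

All three share one core and differ only in the group on a saturated chain carbon bound to an amine nitrogen in a ring. In a functional assay on the whole organism for antagonist activity, with Mus musculus as the target (a higher number here means that more compound is needed for the effect, a lower number that less compound is needed), compound 1 reaches only a limit, > 10 mg/kg. Compound 3 stands as the highest of the two real numbers shown; its nearest neighbour is compound 2, and the step of a 4.8-fold higher number from compound 2 to compound 3 (0.68 log units; beyond the scatter). The step of an at least 3.4-fold lower number from compound 1 to compound 3 (0.53 log units; beyond the scatter), and the step of an at least 16-fold lower number from compound 1 to compound 2 (1.22 log units; beyond the scatter), so both ring groups sit well away from the limit of > 10 mg/kg in this assay, at which 1 of the 3 values shown sits.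

Compound 4, `COc1cc(N)c(Cl)cc1NC(=O)C1CCN(Cc2ccccc2)CC1`, is not yet measured. It differs from compound 3 by phenyl in place of cyclohexyl on a saturated chain carbon bound to an amine nitrogen in a ring. Going by the values given here, the one measured step that bears on it is the one from a six-membered aromatic ring to the saturated ring, a 4.8-fold higher number from compound 2 to compound 3 (0.68 log units; beyond the scatter), which ran toward a higher number; compound 4 carries the aromatic ring of compound 2 without its fluorine. The expected step is therefore a 2.9-fold lower number from compound 3 to compound 4 (0.46 log units; beyond the scatter), a modest fall rather than none. Compound 4 is estimated at 1 mg/kg, with a range from 0.4 mg/kg to 3 mg/kg.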

Compound 4, dose for half-maximal effect: 0.5 mg/kg
For compound 4 the middle estimate is 2.0-fold (0.30 log units) above the measured one; measured number inside the range.
By their numbers in this assay, from the lowest: compounds 4 and 2 (each within the scatter of the next); then compound 3. At a limit, above all of these: compound 1.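

In this assay, the comparison of cyclohexyl and phenyl, two rings with the same count of heavy atoms, shows that an aromatic ring at this position goes with a lower number even with no fluorine on it (a 5.8-fold lower number from compound 3 to compound 4 (0.76 log units; beyond the scatter)). The fluorine of compound 2 therefore turns out not to be needed for that result, since removing it leaves the two compounds indistinguishable (a 1.2-fold lower number from compound 2 to compound 4 (0.08 log units; within the scatter)). From the compounds shown here alone, compound 1 gives a limit rather than a number, so the step to the phenyl group is a minimum, and its true size stays unknown (an at least 20-fold lower number from compound 1 to compound 4 (1.30 log units; beyond the scatter)): (the limit of > 10 mg/kg in this assay, at which 1 of the 4 values shown sits).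

Fluoro is the only group shown on the phenyl ring, so it remains open whether a chloro or methoxy group there, a pyridyl ring in place of phenyl, or a phenethyl group in place of benzyl would change the dose needed. With only this assay to go on, the numbers also cannot show why the aromatic ring goes with less compound being needed, or whether the same order would hold in a test on isolated cells.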